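The source may report more compounds than this note shows. Statements on the series, on what has been measured and on what is new or still open speak of the compounds shown alone.

Measured so far in a functional assay on PC-3 cells (Homo sapiens) for cytotoxicity, read by MTT assay, with a stated time of 72 h; a lower number here means a stronger inhibitor of growth, a higher number a weaker inhibitor of growth:

- compound 1, `CC(C)COC(=O)Nc1ccc([Se][Se]c2ccc(NC(=O)OCC(C)C)cc2)cc1`: 48900 nM
- compound 2, `CCCOC(=O)Nc1ccc([Se]C#N)cc1`: 47400 nM
- compound 3, `O=C(Nc1ccc([Se][Se]c2ccc(NC(=O)Oc3ccccc3)cc2)cc1)Oc1ccccc1`: 27200 nM

All three numbers sit close together. Compound 2 holds the second highest of the three; its nearest neighbour is compound 1, within the scatter, and its furthest is compound 3, also within the scatter, so no ordering among the three can be claimed.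

Compound 4, `N#C[Se]c1ccc(NC(=O)Oc2ccccc2)cc1`, has not yet been measured in this assay. It differs from compound 2 by phenyl in place of propyl on an oxygen next to a carbonyl group. Going by the values given here, no pair of measured compounds shows exactly this step. Among the compounds with values here, the only related comparison is between compound 1 and compound 3, which carry different groups on the same oxygen within a shared diselenide core; their values lie within the scatter of each other, so they give no sign of a change beyond scatter.

On that basis the step of a 1.5-fold lower number from compound 2 to compound 4 (0.17 log units; within the scatter) is expected to be small, if anything a slight lowering, and not beyond the scatter. Compound 4 is therefore estimated at 32000 nM in this assay, within a range of 12000 nM to 80000 nM.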

Compound 4, concentration for total growth inhibition: 37500 nM
For compound 4 the middle estimate is 1.2-fold (0.07 log units) below the measured one, within the range that was stated.
By their numbers in this assay, from the lowest: compounds 3, 4, 2 and 1 (each within the scatter of the next).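

In this assay, going by these compounds alone, the change from propyl to phenyl on an oxygen next to a carbonyl group gives a 1.3-fold lower number from compound 2 to compound 4 (0.10 log units; within the scatter), the first reading of this change in a pair differing in this one place. At this position, then, a six-membered aromatic ring can stand in place of a three-carbon chain with no shift beyond the scatter in growth inhibition, at least for this pair. No other measurement bearing on this result is available.

On these data alone, whether a longer chain, a benzyl group or a phenyl ring carrying a carboxylic acid on this oxygen would move the number beyond the scatter remains open. Also open is whether the same change would read alike in the diselenide compounds, as the compounds shown contain no such pair.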